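2,6-Dibromophenyl in place of 2,6-dichlorophenyl

The source may report more compounds than this note shows. Statements on the series, on what has been measured and on what is new or still open speak of the compounds shown alone.

Three compounds measured in a physicochemical assay for solubility, in phosphate buffer, measured as kinetic solubility, at pH 7.4 (a higher number here means a more soluble compound, a lower number a less soluble compound), each gave only a limit:
Compound 1 `Cc1oc(-c2ccccc2Cl)nc1CN1CCC(C(=O)NCCCN2C[C@H](C)C[C@H](C)C2)CC1` limit of > 72 ug/mL
Compound 2 `Cc1oc(-c2c(Cl)cccc2Cl)nc1CN1CCC(C(=O)NCCCN2C[C@H](C)C[C@H](C)C2)CC1` limit of > 77 ug/mL
Compound 3 `Cc1ccccc1-c1nc(CN2CCC(C(=O)NCCCN3[C@H](C)CCC[C@@H]3C)CC2)c(C)o1` limit of > 69 ug/mL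

Compound 2 stands at the limit > 77 ug/mL and so has no number, and the other two values are limits as well. Compound 4 `Cc1oc(-c2c(Br)cccc2Br)nc1CN1CCC(C(=O)NCCCN2C[C@H](C)C[C@H](C)C2)CC1` carries the change 2,6-dibromophenyl in place of 2,6-dichlorophenyl on an aromatic carbon with 2,6-dibromophenyl in place of 2,6-dichlorophenyl on an aromatic carbon. Among the compounds with values here, the one measured step that bears on it is a step that the two limits leave unreadable from compound 1 to compound 2 with chloro in place of hydrogen on an aromatic carbon, and it offers no size to carry over. The estimated step that the limit leaves unreadable from compound 2 to compound 4 stays within the usual scatter in this assay and has no expected direction. For compound 4 the expected value is 85 ug/mL with an estimated range from 45 ug/mL to 95 ug/mL in this read-out.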

Compound 4, solubility: 62.4 ug/mL
For compound 4 the middle estimate is 1.4-fold (0.13 log units) above the measured one; measured number inside the range.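

In this assay, within the data shown here, compound 4 gives the first true number for a group at this position, 62.4 ug/mL. The earlier compounds shown here gave only limits. The change to 2,6-dibromophenyl from 2,6-dichlorophenyl gives an at least 1.2-fold lower number from compound 2 to compound 4 (0.09 log units; that floor lies within the scatter), and the change from 2-chlorophenyl gives an at least 1.1-fold lower number from compound 1 to compound 4 (0.06 log units; that floor lies within the scatter). Both steps are floors only, so they set a lower bound on the drop, and its true size cannot be read.

From the compounds shown here alone, how far compound 1 and compound 2 actually lie beyond their limits remains open. So does the outcome in this assay for a methoxy or an amine in place of the two bromines.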